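A few compounds are considered here, and "the series" means these few. Any claim that something is new, unique, unknown or untested is made for them only; others in the source may bear on it.

Measured values in a functional assay on A549 cells (Homo sapiens) for cytotoxicity, read by CCK-8 assay, with a stated time of 24 h; on this read-out higher numbers stand for weaker inhibition and lower numbers for stronger inhibition:

- compound 1 `C/C(=C\c1nc(-c2ccccc2)cs1)C(N)=O`: > 50000 nM, a limit of this assay, not a number
- compound 2 `C/C(=C\c1nc(-c2ccc(C)cc2)cs1)C(N)=O`: > 50000 nM, likewise a limit
- compound 3 `C/C(=C\c1cccc(-c2ccccc2)c1)C(N)=O`: > 50000 nM, likewise a limit

From compound 1 to compound 2 the change is methyl in place of hydrogen on an aromatic carbon. The step that the two limits leave unreadable from compound 1 to compound 2 is left unreadable, because both values sit at the limit of > 50000 nM in this assay, at which 3 of the 3 values shown sit. Compound 3 carries a core different from that of compound 1; the difference between the two cores is not broken down here.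

Compound 4 `C/C(=C\c1cccc(-c2ccc(C)cc2)c1)C(N)=O` is not yet measured. It differs from compound 3 by methyl in place of hydrogen on an aromatic carbon, the same change as that from compound 1 to compound 2, at a place described in the same words. Compound 3 stands only at a limit in this assay, with no number to move from.

For compound 4 the expected step that the limit leaves unreadable from compound 3 to compound 4 rests on the earlier step that the two limits leave unreadable from compound 1 to compound 2, which gave no readable size. Compound 4 is therefore estimated at 60000 nM, within 20000 nM to 200000 nM, and the assay is expected most likely to report a limit again.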

Compound 4, half-maximal inhibitory concentration: 5100 nM
The estimate for compound 4 lay 12-fold (1.07 log units) above the measured number, and the stated range ends above it.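

In this assay, methyl in place of hydrogen on an aromatic carbon gives an at least 9.8-fold lower number from compound 3 to compound 4 (0.99 log units; beyond the scatter), a step beyond the scatter and, on the core of compound 3, the first readable effect in this series. The same change on the core of compound 1 cannot be read, because compound 1 and compound 2 both sit at a limit, not a number: the limit of > 50000 nM in this assay, at which 3 of the 4 values shown sit. The transfer between cores is therefore neither confirmed nor refuted: the data show that the change can matter on the core of compound 3, but not whether it has any effect on the core of compound 1, and this rests on a single pair.

The compounds shown leave open whether another group at this place, such as an amine, a carboxylic acid or a longer chain, would give a lower number than methyl does. They also leave open whether any group could bring the core of compound 1 to a readable value in this assay.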